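Removing the aromatic amino group in the fluorinated analog

The source may report more compounds than this note shows. Statements on the series, on what has been measured and on what is new or still open speak of the compounds shown alone.

For the measured compounds named here, compound 2 `C=CC[C@H]1C[C@]2([C@@H](C)Cc3cc(N)c(OC)cc3F)OCOC2=CC1=O` gives 160 nM in a functional assay on NCI-H460 cells (Homo sapiens) for antiproliferative activity, with a stated time of 72 h (on this read-out lower numbers stand for stronger inhibition and higher numbers for weaker inhibition), the higher of the two numbers so far; compound 1 `C=CC[C@H]1C[C@]2([C@@H](C)Cc3ccc(OC)cc3)OCOC2=CC1=O` gives 90 nM in this assay, a gap within the scatter. Compound 3 `C=CC[C@H]1C[C@]2([C@@H](C)Cc3ccc(OC)cc3F)OCOC2=CC1=O` differs from compound 2 by hydrogen in place of amino on an aromatic carbon. Going by the values given here, no measured pair shows this change on its own, and compound 1 lacks both the fluoro and the amino group, so the comparison of compound 1 with compound 2 gives only an indirect hint. The change is expected to give only a small step toward a lower number, a 1.5-fold lower number from compound 2 to compound 3 (0.16 log units; within the scatter), within the scatter. Compound 3 is estimated at 110 nM, range 50 nM to 250 nM.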

Compound 3, half-maximal inhibitory concentration: 94 nM
Beside the measured number, compound 3's estimate is 1.2-fold (0.07 log units) above it; the range from low to high includes it.
By their numbers in this assay, from the lowest: compounds 1, 3 and 2 (each within the scatter of the next).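

Hydrogen in place of amino, ortho to a methoxy group and para to a fluoro group, gives a 1.7-fold lower number from compound 2 to compound 3 (0.23 log units; within the scatter) in this assay and is the first direct reading at this position. Fluoro in place of hydrogen gives a 1.0-fold higher number from compound 1 to compound 3 (0.02 log units; within the scatter) and so can now also be read on its own. No measurement available here accounts for either step.

Going by these compounds, whether a hydroxyl or a dimethylamino group at the amino position would give a step beyond the scatter stays open. So does whether chloro in place of fluoro would.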